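The source may hold more compounds than are shown below. What is called first, only, known or untested is meant among the compounds shown, and "the series" means these compounds.

Of the compounds shown here, three built on a shared core have been measured so far in a functional assay on A549 cells (Homo sapiens) for cytotoxicity, read by MTT assay, with a stated time of 48 h; a higher number here means a weaker inhibitor, a lower number a stronger inhibitor. There, compound 1 (`C=C1CCC[C@]2(C)CCC(C=O)=CC[C@@]12C`) gives 145000 nM and compound 3 (`C=C1CCC[C@]2(C)CCC(c3cn(CC(=O)Nc4ccc(C)cc4)nn3)=CC[C@@]12C`) gives 270000 nM, two values within the scatter of each other. Compound 2 (`C=C1CCC[C@]2(C)CCC(c3cn(-c4cccc([N+](=O)[O-])c4)nn3)=CC[C@@]12C`), which carries a 3-nitrophenyl group, gives 24700 nM as the lowest of the three numbers, and its gaps to both of the others lie beyond the scatter.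

Compound 4 (`C=C1CCC[C@]2(C)CCC(c3cn(-c4cccc(OC)c4)nn3)=CC[C@@]12C`) has not yet been measured. It differs from compound 2 by methoxy in place of nitro on an aromatic carbon, which turns 3-nitrophenyl into 3-methoxyphenyl. Within the data shown here, no measured pair isolates this change, so the data give no direct size for it. Compound 2 at 24700 nM already holds the lowest number and the other two compounds lie well above it, so an upward move is the more likely direction in this assay. The expected change is a modest rise, estimated as a 2.4-fold higher number from compound 2 to compound 4 (0.39 log units; beyond the scatter) and only a little beyond the scatter. For compound 4 the estimated value is 60000 nM with an expected range from 20000 nM to 180000 nM once it is measured.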

Compound 4, half-maximal inhibitory concentration: 11200 nM
The estimate for compound 4 lay 5.4-fold (0.73 log units) above the measured number, outside the stated range (below it).
By their numbers in this assay, from the lowest: compound 4; then compound 2; then compounds 1 and 3 (each within the scatter of the next).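

In this assay, among these compounds, putting methoxy in place of nitro on this aromatic carbon gives a 2.2-fold lower number from compound 2 to compound 4 (0.34 log units; beyond the scatter) and so puts a measured size on a change that no earlier pair of compounds had isolated. The step is modest but beyond the scatter, and it shows that the nitro group is not needed here for a low number: compound 2 gives 24700 nM in this assay with nitro, and compound 4 goes lower still, to 11200 nM in the same assay, with methoxy. The data shown offer no measurement that explains why the number moves in this direction.

A single pair on one aromatic carbon cannot tell whether this lower number is particular to methoxy or would also appear with other groups in that place, such as an amine, a hydroxyl group or a chlorine atom. It also leaves open whether a longer ether such as ethoxy would extend the step, hold it or reverse it.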